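Compound 2 to compound 4: phenyl for 2,4-difluorophenyl

A few compounds are considered here, and "the series" means these few. Any claim that something is new, unique, unknown or untested is made for them only; others in the source may bear on it.

For the measured compounds named here, compound 2 (`CC1(c2ccccc2)CCN(c2cccc(-c3ccc(F)cc3F)c2)C(=O)O1`) gives 1.25 h in an in vitro ADME assay on microsomes from liver (Rattus norvegicus) for metabolic stability (on this read-out higher numbers stand for a longer-lived compound and lower numbers for a shorter-lived compound), and holds the highest of the three numbers measured so far. In this assay compound 3 (`C[C@@H](c1ccc(-c2ccc(F)cc2F)cc1)N1CC[C@](CCC(N)=O)(c2ccc(F)cc2)OC1=O`) reads 0.417 h and compound 1 (`C[C@@H](c1ccc(-c2ccc(F)cc2F)cc1)N1CC[C@](CCO)(c2ccccc2)OC1=O`) reads 0.267 h as their half-lives, and both lie below compound 2 by more than the scatter.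

The next compound to be measured is compound 4 (`CC1(c2ccccc2)CCN(c2cccc(-c3ccccc3)c2)C(=O)O1`). It differs from compound 2 in one place (phenyl in place of 2,4-difluorophenyl on an aromatic carbon): phenyl in place of 2,4-difluorophenyl on an aromatic carbon, meta to a large group.

Going by the values given here, all three measured compounds carry the 2,4-difluorophenyl group, so no measured pair shows this replacement, and the expectation has no direct precedent. Compound 2 (1.25 h) is the closest reference, and since it tops the three numbers, a lower value is the likelier side. The change expected in this assay is therefore small and downward, within the scatter or close to its edge. The expected step is a 1.6-fold lower number from compound 2 to compound 4 (0.19 log units; within the scatter) and it carries wide uncertainty. For compound 4 the estimated half-life is 0.8 h (expected range 0.35 h to 1.6 h).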

Compound 4, half-life: 0.267 h
Compound 4: the middle estimate sits 3.0-fold (0.48 log units) above what was measured; the measured number lies below the stated range.
By their numbers in this assay, from the lowest: compounds 1, 4 and 3 (each within the scatter of the next); then compound 2.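

In this assay, the pair gives the series its first direct reading of this replacement: a 4.7-fold lower number from compound 2 to compound 4 (0.67 log units; beyond the scatter). At this aromatic carbon, meta to a large group, the 2,4-difluorophenyl group and phenyl are therefore not interchangeable on the core of compound 2, something that compounds sharing the 2,4-difluorophenyl group could not show. This reading rests on one pair and one core, and nothing shown accounts for the size of the step.

Going by these compounds, it remains open whether both fluorines are needed to hold the longer half-life, or whether a phenyl carrying a single fluorine, a chlorophenyl or a pyridyl ring would read like compound 2 or like compound 4. Also open, on these data alone, is whether the same replacement gives a step of similar size on the cores of compound 1 and compound 3, where the 2,4-difluorophenyl group sits on a differently substituted framework.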